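Compound 3 to compound 4: swapping the acyl amine group

This account rests on a few compounds, and the source may have more. Where it says the series, first, only, none or still open, it means among the compounds named here.

Measured in an in vitro ADME assay on microsomes (Mus musculus) for metabolic stability; a lower number here means that the compound disappears faster, a higher number that the compound lasts longer:
- compound 1 `Cc1c2c(n3c1CCN(C(=O)[C@H](C)N)CC[C@H](C)Nc1cc-3ccc1C(N)=O)CC(C)(C)CC2=O` (> 0.5 h)
- compound 2 `CC(=O)N1CCc2c(C)c3c(n2-c2ccc(C(N)=O)c(c2)N[C@@H](C)[C@H](C)C1)CC(C)(C)CC3=O` (0.0667 h)
- compound 3 `CC[C@H](N)C(=O)N1CCc2c(C)c3c(n2-c2ccc(C(N)=O)c(c2)N[C@@H](C)[C@H](C)C1)CC(C)(C)CC3=O` (0.383 h)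

The value for compound 1 (> 0.5 h) is a limit of the assay, not a number. Of the two actual numbers, the higher belongs to compound 3 (0.383 h), and the lower to compound 2 (0.0667 h).

Compound 4 `Cc1c2c(n3c1CCN(C(=O)C(C)(C)N)C[C@@H](C)[C@H](C)Nc1cc-3ccc1C(N)=O)CC(C)(C)CC2=O` is not yet measured. It carries 1-amino-1-methylethyl in place of 1-aminopropyl on a carbonyl carbon. Among the measured compounds shown here, one measured step bears on this place: putting 1-aminopropyl in place of methyl gave a modest change beyond the scatter (a 5.7-fold higher number from compound 2 to compound 3 (0.76 log units; beyond the scatter)). That step added the amino-bearing group, whereas the new change only rearranges it, so a much smaller effect in this assay is expected, with no clear direction. The expected change is none beyond the scatter (a 1.0-fold higher number from compound 3 to compound 4 (0.02 log units; within the scatter)). The estimated half-life of compound 4 is 0.4 h (expected range 0.18 h to 0.85 h).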

Compound 4, half-life: 0.367 h
Beside the measured number, compound 4's estimate is 1.1-fold (0.04 log units) above it; low and high end bracket the measured number.
By their numbers in this assay, from the lowest: compound 2; then compounds 4 and 3 (each within the scatter of the next). At a limit, above all of these: compound 1.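

In this assay, 1-amino-1-methylethyl in place of 1-aminopropyl on the carbonyl carbon leaves the number within the scatter: a 1.0-fold lower number from compound 3 to compound 4 (0.02 log units; within the scatter). The defined stereocentre of 1-aminopropyl, absent from 1-amino-1-methylethyl, therefore makes no readable difference at this position in this assay. The rise over the methyl group also appears with a second amino-bearing group, a 5.5-fold higher number from compound 2 to compound 4 (0.74 log units; beyond the scatter), so it no longer rests on 1-aminopropyl alone.

Whether the amine itself accounts for that rise stays open, as would be tested by a hydroxyl group or an unsubstituted longer chain on the carbonyl carbon. Compound 1 gives > 0.5 h, which is a limit, so how far it lies above the other compounds cannot be read: the limit of > 0.5 h in this assay, at which 1 of the 4 values shown sits.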